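Chloro to methyl on the anilino phenyl ring

A few compounds are considered here, and "the series" means these few. Any claim that something is new, unique, unknown or untested is made for them only; others in the source may bear on it.

Compound 1 `c1ccc(Nc2ccc(N3CC4CC(C3)N4)nn2)cc1`: 441 nM
Compound 2 `Clc1ccc(Nc2ccc(N3CC4CC(C3)N4)nn2)cc1`: 90.4 nM

In an assay on cell membranes for displacement of a labelled ligand from Neuronal acetylcholine receptor; alpha4/beta2 (Rattus norvegicus) (on this read-out higher numbers stand for weaker inhibition and lower numbers for stronger inhibition), compound 2 gives the lower of the two numbers shown; the step of a 4.9-fold lower number from compound 1 to compound 2 (0.69 log units; beyond the scatter) sets it apart from compound 1, and no step here lies within the scatter. Compound 3 `Cc1ccc(Nc2ccc(N3CC4CC(C3)N4)nn2)cc1` differs from compound 2 by methyl in place of chloro on an aromatic carbon. Within the data shown here, only one measured step bears on this position, and it concerns hydrogen against chloro, not methyl; methyl itself is untested. A modest move back toward compound 1 is expected, giving a 2.2-fold higher number from compound 2 to compound 3 (0.34 log units; beyond the scatter). Compound 3 is therefore estimated at 200 nM, in the range 80 nM to 500 nM.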

Compound 3, inhibition constant: 44.3 nM
Compound 3: the middle estimate sits 4.5-fold (0.65 log units) above what was measured; the measured number lies below the stated range.
By their numbers in this assay, from the lowest: compound 3; then compound 2; then compound 1.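

In this assay the place para to a large group separates methyl from chloro, and the change runs further from hydrogen rather than back toward it (a 2.0-fold lower number from compound 2 to compound 3 (0.31 log units; beyond the scatter)). Against the unsubstituted ring, methyl gives the largest step seen at this place (a 10-fold lower number from compound 1 to compound 3 (1.00 log units; beyond the scatter)). Among the three groups shown, the order from the lowest number is therefore methyl, chloro, hydrogen.

As far as these compounds go, how an ethyl, a methoxy or an amine at this place would rank remains open. From the compounds shown here alone, what underlies the order also remains open, as nothing measured here bears on it.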